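Replacing 3-carboxypyrrolidin-1-yl with hydroxy on a shared core

The source may report more compounds than this note shows. Statements on the series, on what has been measured and on what is new or still open speak of the compounds shown alone.

- Compound 1 `COc1ccc(/C=C\c2cc(OC)c(OC)c(OC)c2)cc1OCc1ccc(CNC(C)(C)C(=O)O)cc1`: > 10000 nM (a limit)
- Compound 2 `COc1ccc(/C=C\c2cc(OC)c(OC)c(OC)c2)cc1OCc1ccc(C=O)cc1`: 900 nM
- Compound 3 `COc1ccc(/C=C\c2cc(OC)c(OC)c(OC)c2)cc1OCc1ccc(CN2CC[C@H](C(=O)O)C2)cc1`: > 10000 nM (a limit)

All three results come from a functional assay on MC-38 cells (Mus musculus) for antiproliferative activity, read by CCK-8 assay, with a stated time of 48 h; a lower number here means a stronger inhibitor, a higher number a weaker inhibitor. Compound 3 gives only > 10000 nM, which is a limit and not a number. Compound 4 `COc1ccc(/C=C\c2cc(OC)c(OC)c(OC)c2)cc1OCc1ccc(CO)cc1` carries hydroxy in place of 3-carboxypyrrolidin-1-yl on a saturated chain carbon bound to an aromatic carbon. Going by the values given here, two measured steps bear on this change, an at least 11-fold higher number from compound 2 to compound 3 (1.04 log units; beyond the scatter) and an at least 11-fold lower number from compound 1 to compound 2 (1.04 log units; beyond the scatter). Both are large, and they run in opposite directions around compound 2. A large fall in the number is therefore expected, towards the level of compound 2 at 900 nM. The expected change is an at least 8.3-fold lower number from compound 3 to compound 4 (0.92 log units; beyond the scatter). Compound 4 is estimated at 1200 nM, with an expected range of 350 nM to 4500 nM.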

Compound 4, half-maximal inhibitory concentration: 5700 nM
Beside the measured number, compound 4's estimate is 4.8-fold (0.68 log units) below it; the measured number lies above the stated range.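

Hydroxymethyl at this position gives a readable number in this assay, but it falls clearly short of the formyl group, with a 6.3-fold higher number from compound 2 to compound 4 (0.80 log units; beyond the scatter). Against the two groups carrying a carboxylic acid, the steps are an at least 1.7-fold lower number from compound 3 to compound 4 (0.24 log units; that floor lies within the scatter) and an at least 1.7-fold lower number from compound 1 to compound 4 (0.24 log units; that floor lies within the scatter), so neither shows a firm gain. These floors stay small because compound 1 and compound 3 give only a limit, not a number: the limit of > 10000 nM in this assay, at which 2 of the 4 values shown sit.

On these data alone, it remains open whether the amine or the carboxylic acid matters more in those two compounds. A plain aminomethyl group, or a carboxylic acid set directly on the aromatic carbon, would help separate the two.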